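This account rests on a few compounds, and the source may have more. Where it says the series, first, only, none or still open, it means among the compounds named here.

Compound 3 `COc1cccc(-c2c(S(=O)(=O)c3cccc(C#N)c3)cnc3cc(F)ccc23)c1` gives 1.83 mL/min in an ADME assay on microsomes from liver (Homo sapiens) for metabolic stability, tested at 2.5 uM (on this read-out higher numbers stand for fast clearance and lower numbers for slow clearance), the highest of the three numbers shown so far. Going by the values given here, compound 1 `COc1cccc(-c2c(S(=O)(=O)c3cc(F)cc(F)c3)cnc3cc(F)ccc23)c1` gives 1.81 mL/min, within the scatter of compound 3, while compound 2 `O=S(=O)(c1cc(Cl)cc(Cl)c1)c1cnc2cc(F)ccc2c1-c1ccc(F)cc1` gives 0.18 mL/min, a markedly lower number; compound 2 differs from compound 3 in two places, and no single step links them. The next compound is compound 4 `COc1cccc(-c2c(S(=O)(=O)c3cc(Cl)cc(Cl)c3)cnc3cc(F)ccc23)c1`, where (3,5-dichlorophenyl in place of 3-cyanophenyl on a sulfonyl sulfur). Among the compounds with values here, the one step that bears on this position, a 1.0-fold higher number from compound 1 to compound 3 (0.00 log units; within the scatter), was flat. Compound 2, which carries the same 3,5-dichlorophenyl on its sulfonyl sulfur, is the only pointer toward a lower number, and its second difference is not separated. Compound 4 is expected to come out somewhat lower, a 1.8-fold lower number from compound 3 to compound 4 (0.26 log units; within the scatter). The estimate for compound 4 is 1 mL/min, with a range from 0.3 mL/min to 3 mL/min.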

Compound 4, intrinsic clearance in a liver preparation (reported as CLH), per the amount of preparation that the assay uses: 1.51 mL/min
Compound 4: middle estimate off by 1.5-fold (0.18 log units), on the low side; measured number inside the range.
By their numbers in this assay, from the lowest: compound 2; then compounds 4, 1 and 3 (each within the scatter of the next).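

With 3-methoxyphenyl held on the shared core, the group on the sulfonyl sulfur has shown no effect beyond the scatter in this assay, now including 3,5-dichlorophenyl (a 1.2-fold lower number from compound 3 to compound 4 (0.08 log units; within the scatter); a 1.2-fold lower number from compound 1 to compound 4 (0.08 log units; within the scatter)). With 3,5-dichlorophenyl held on the sulfonyl sulfur, the aromatic carbon emerges as the place that moves the read-out, with 3-methoxyphenyl in place of 4-fluorophenyl (an 8.4-fold higher number from compound 2 to compound 4 (0.92 log units; beyond the scatter)). No evidence on hand accounts for this step.

From the compounds shown here alone, whether 4-fluorophenyl gives a similar step with 3-cyanophenyl or 3,5-difluorophenyl on the sulfonyl sulfur remains open. Also open, going by these compounds, is whether an aminophenyl or a carboxyphenyl on that sulfur would leave the read-out as flat.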